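Cyano for Chloro on a Nucleotide P2Y2 Agonist

The source may hold more compounds than are shown below. What is called first, only, known or untested is meant among the compounds shown, and "the series" means these compounds.

Measured so far:
compound 1 `O=c1c2ccccc2ccn1[C@@H]1O[C@H](COP(=O)(O)OP(=O)(O)OP(=O)(O)O)[C@@H](O)[C@H]1O` with 31 nM in a functional assay for agonist activity at P2Y purinoceptor 2 (Homo sapiens), read by FLIPR; on this read-out higher numbers stand for an effect only at larger amounts of compound and lower numbers for an effect already at smaller amounts;
compound 2 `O=c1c2cc(Cl)ccc2ccn1[C@@H]1O[C@H](COP(=O)(O)OP(=O)(O)OP(=O)(O)O)[C@@H](O)[C@H]1O` with 10 nM in this assay.

Compound 2 stands at the lowest of the two numbers; the nearest is compound 1, and the step between them is a 3.1-fold lower number from compound 1 to compound 2 (0.49 log units; beyond the scatter), a chloro in place of hydrogen on an aromatic carbon.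

Compound 3 `N#Cc1ccc2ccn([C@@H]3O[C@H](COP(=O)(O)OP(=O)(O)OP(=O)(O)O)[C@@H](O)[C@H]3O)c(=O)c2c1` has not yet been measured. It differs from compound 2 by cyano in place of chloro on an aromatic carbon; the substituent sits on an aromatic carbon of a six-membered aromatic ring of carbon only, part of a fused or bridged system of two rings, meta to a fused ring and para to a fused ring.

Among the measured compounds shown here, only one measured step bears on this position, and it concerns the entry of chloro, not its exchange for cyano. It tells that a substituent at this place is tolerated and moved the number downward, but gives no direct guide to cyano against chloro. Compound 3 is therefore expected to stay close to compound 2, with no step beyond the scatter: the expected step is a 1.5-fold higher number from compound 2 to compound 3 (0.18 log units; within the scatter). The estimate for compound 3 is 15 nM, in the range 5 nM to 45 nM.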

Compound 3, half-maximal effective concentration: 12 nM
For compound 3 the middle estimate is 1.3-fold (0.10 log units) above the measured one, within the range that was stated.
By their numbers in this assay, from the lowest: compounds 2 and 3 (each within the scatter of the next); then compound 1.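

In this assay the exchange of chloro for cyano is a step within the scatter (a 1.2-fold higher number from compound 2 to compound 3 (0.08 log units; within the scatter)), so at this aromatic carbon the two groups cannot be told apart, although cyano brings two heavy atoms, a triple bond and a hydrogen-bond acceptor where chloro had one heavy atom and no acceptor. The earlier pair showed only that chloro could enter here (a 3.1-fold lower number from compound 1 to compound 2 (0.49 log units; beyond the scatter)); now cyano in place of hydrogen also gives a step beyond the scatter (a 2.6-fold lower number from compound 1 to compound 3 (0.41 log units; beyond the scatter)), so among the compounds shown the lower number at this position is not tied to chloro alone. Nothing at hand explains why the two groups read alike.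

On these data alone, what stays open is how wide the tolerance at this position is: how an amine, a carboxylic acid or a longer chain on this same carbon would read in this assay cannot be told from these compounds. Also open is whether chloro and cyano would read alike on the other carbons of this six-membered aromatic ring, since the compounds shown carry a substituent at this one place only.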